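Cycloheptyl for Cyclohexylmethyl: an Expected Small Step

This account rests on a few compounds, and the source may have more. Where it says the series, first, only, none or still open, it means among the compounds named here.

Compound 1 `O=C(O)c1ccccc1-c1ccc(CCc2ncc(CCc3ccccc3)[nH]2)cc1` gives 1320 nM in an in vitro functional assay on cells for agonist activity at Bombesin receptor subtype-3 (Homo sapiens), read by luminescence and calcium flux; on this read-out higher numbers stand for an effect only at larger amounts of compound and lower numbers for an effect already at smaller amounts. Compound 2 `O=C(O)c1ccccc1-c1ccc(CCc2ncc(CCC3CCCCC3)[nH]2)cc1` gives 642 nM in this assay, and the step of a 2.1-fold lower number from compound 1 to compound 2 (0.31 log units; beyond the scatter) is the only measured one. Within the data shown here, compound 2 thus stands at the lower of the two numbers measured so far, with compound 1 as its only comparison.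

Compound 3 `O=C(O)c1ccccc1-c1ccc(CCc2ncc(CC3CCCCCC3)[nH]2)cc1` differs from compound 2 by cycloheptyl in place of cyclohexylmethyl on a saturated chain carbon bound to an aromatic carbon. Among the measured compounds shown here, the one measured step, a 2.1-fold lower number from compound 1 to compound 2 (0.31 log units; beyond the scatter), concerns a different exchange, and no measured pair shows what redistributing the same atoms between ring and chain does. The expected step is therefore a 1.1-fold higher number from compound 2 to compound 3 (0.04 log units; within the scatter), none beyond the scatter. For the measured compounds named here, compound 3 is accordingly expected to give 700 nM in this assay, with a range from 250 nM to 2000 nM to reflect that the change has no direct precedent among the measured compounds.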

Compound 3, half-maximal effective concentration: 88 nM
Compound 3: the middle estimate sits 8.0-fold (0.90 log units) above what was measured, outside the stated range (below it).
By their numbers in this assay, from the lowest: compound 3; then compound 2; then compound 1.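

In this assay, rearranging the same atoms from cyclohexylmethyl into cycloheptyl gives a 7.3-fold lower number from compound 2 to compound 3 (0.86 log units; beyond the scatter) on a saturated chain carbon bound to an aromatic carbon, so here the way the atoms are joined matters even with heavy atoms, hydrogen-bond donors, hydrogen-bond acceptors and charge all unchanged. Measured against benzyl, the same cycloheptyl gives a 15-fold lower number from compound 1 to compound 3 (1.18 log units; beyond the scatter) and thereby opens a much wider span at this place than the single earlier step had shown. No supporting measurement is at hand to say why the rearrangement has so large an effect.

The compounds shown leave open whether the gain is particular to cycloheptyl or extends to other rings here, such as cyclopentyl or cyclooctyl. They also leave open how an oxygen-containing ring such as tetrahydropyranyl would fare at this place.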